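Half-life after a swap at one aromatic carbon

The source may hold more compounds than are shown below. What is called first, only, known or untested is meant among the compounds shown, and "the series" means these compounds.

compound 1 `O=S(=O)(Nc1ncccn1)c1ccc2c(c1)OCC[C@@H]2c1ccc(C(F)(F)F)cc1-c1ccc(F)nc1`: 3.2 h
compound 2 `Cn1nccc1-c1cc(C(F)(F)F)ccc1[C@H]1CCOc2cc(S(=O)(=O)Nc3nccs3)ccc21`: 2 h
compound 3 `O=S(=O)(Nc1nccs1)c1ccc2c(c1)OCC[C@@H]2c1ccc(C(F)(F)F)cc1-n1ccnn1`: 0.4 h

In an ADME assay on the whole organism (Mus musculus, strain BALB/c) for metabolic stability, read by LC-MS, with a stated time of 24 h, at a dose of 1 mg/kg by the intravenous route (a higher number here means that the compound lasts longer, a lower number that the compound disappears faster), compound 3 gives 0.4 h and stands lowest of the three. Compound 4 `O=S(=O)(Nc1nccs1)c1ccc2c(c1)OCC[C@@H]2c1ccc(C(F)(F)F)cc1-c1ccc(F)nc1` carries 6-fluoropyridin-3-yl in place of 1H-1,2,3-triazol-1-yl on an aromatic carbon and is otherwise unchanged. Going by the values given here, one measured step concerns that carbon: a 5.0-fold lower number from compound 2 to compound 3 (0.70 log units; beyond the scatter) is a modest fall beyond the scatter, with 1H-1,2,3-triazol-1-yl entering in place of 1-methyl-1H-pyrazol-5-yl. Compound 1 already bears 6-fluoropyridin-3-yl and gives 3.2 h but differs from compound 4 elsewhere in the structure. The expected step is a 5.0-fold higher number from compound 3 to compound 4 (0.70 log units; beyond the scatter) and so a rise of similar size beyond the scatter. Compound 4 is estimated at 2 h (expected range 0.8 h to 4.5 h).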

Compound 4, half-life in the Mus musculus assay: 2.8 h
Beside the measured number, compound 4's estimate is 1.4-fold (0.15 log units) below it; the measured number falls inside the stated range.
By their numbers in the Mus musculus assay, from the lowest: compound 3; then compounds 2, 4 and 1 (each within the scatter of the next).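

In the Mus musculus assay, 6-fluoropyridin-3-yl on this carbon stands well clear of 1H-1,2,3-triazol-1-yl, with a 7.0-fold higher number from compound 3 to compound 4 (0.85 log units; beyond the scatter), while a 1.4-fold higher number from compound 2 to compound 4 (0.15 log units; within the scatter) leaves it not separable from 1-methyl-1H-pyrazol-5-yl. With 6-fluoropyridin-3-yl in place, a 1.1-fold lower number from compound 1 to compound 4 (0.06 log units; within the scatter) leaves 1,3-thiazol-2-yl and pyrimidin-2-yl on the sulfonamide nitrogen not separable either. In a physicochemical assay for solubility (a lower number here means a less soluble compound, a higher number a more soluble compound), compound 3 gives 171000 nM and compound 4 gives 21000 nM. In the physicochemical assay, the same swap on the carbon moves the number the opposite way: the measured solubility of compound 3, 171000 nM, and of compound 4, 21000 nM, an 8.1-fold lower number (0.91 log units; beyond the scatter)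

On these data alone, whether a carboxylic acid or a morpholine on this carbon would give high numbers in both the Mus musculus assay and the physicochemical assay stays open.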